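A Third Sugar Added to a Weak Flavonol Inhibitor

A few compounds are considered here, and "the series" means these few. Any claim that something is new, unique, unknown or untested is made for them only; others in the source may bear on it.

Compound 1 `COc1c(O)cc2oc(-c3ccc(O)c(O)c3)c(O[C@@H]3O[C@H](CO)[C@H](O)[C@H](O)[C@H]3O[C@@H]3OC[C@](O)(CO)[C@H]3O)c(=O)c2c1O` and compound 2 `O=C1C[C@@H](c2ccc(O)cc2)Oc2c(O[C@@H]3O[C@H](CO)[C@@H](O)[C@H](O)[C@H]3O)c(O)cc(O)c21` have been tested in a functional assay on cells (Neutrophil, Homo sapiens), read by ELISA, with stated times of 1 h and 24 h; a higher number here means a weaker inhibitor, a lower number a stronger inhibitor. In this assay compound 1 gives 7200 nM, and compound 2 gives 11400 nM. The gap between these two numbers lies within the usual scatter of repeated measurements, so neither compound can be called the more potent; both are weak inhibitors, and compound 1 simply gives the number that a newcomer would start from.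

Compound 3 `COc1c(O)cc2oc(-c3ccc(O)c(O)c3)c(O[C@@H]3O[C@H](CO)[C@H](O)[C@H](O)[C@H]3O[C@@H]3OC[C@](O)(CO[C@@H]4OC[C@H](O)[C@H](O)[C@H]4O)[C@H]3O)c(=O)c2c1O` has not yet been measured. It differs from compound 1 in one place: 3,4,5-trihydroxyoxan-2-yl in place of hydrogen on an oxygen on a saturated carbon. Among the measured compounds shown here, with only two measured compounds, and no measured pair that differs in a single place, there is no measured step to lean on. The step is therefore estimated at a 1.3-fold higher number from compound 1 to compound 3 (0.10 log units; within the scatter), which is no change beyond the scatter. Compound 3 is expected to give 9000 nM in this assay, within a range of 4000 nM to 20000 nM.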

Compound 3, half-maximal inhibitory concentration: 24500 nM
Beside the measured number, compound 3's estimate is 2.7-fold (0.43 log units) below it, outside the stated range (above it).
By their numbers in this assay, from the lowest: compounds 1 and 2 (each within the scatter of the next); then compound 3.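

Among the compounds shown here, this is the first measured step at this position: with 3,4,5-trihydroxyoxan-2-yl in place of hydrogen on the oxygen of the hydroxymethyl group, this assay shows a 3.4-fold higher number from compound 1 to compound 3 (0.53 log units; beyond the scatter). The step is modest, but it lies beyond the scatter, so this position does respond to the change, and the added ring makes an already weak inhibitor weaker. No evidence bears on why the number rises, so the result stands as an observation only.

From the compounds shown here alone, whether this loss belongs to this particular ring or would follow from any group on that oxygen remains open. A methyl group, an amine on a short chain or a carboxylic acid at the same place could help separate those two readings.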